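Swapping trifluoromethyl for methoxy on compound 2

This account rests on a few compounds, and the source may have more. Where it says the series, first, only, none or still open, it means among the compounds named here.

Of the compounds shown here, two have numbers so far. In a functional assay on A549 cells (Homo sapiens) for antiproliferative activity, read by MTT assay, with a stated time of 48 h (on this read-out lower numbers stand for stronger inhibition and higher numbers for weaker inhibition), compound 1 (`Cc1ccc(-c2cc(NC(=O)/C=C/c3ccc(Cl)cc3)n[nH]2)cc1`) gives 1490 nM and compound 2 (`O=C(/C=C\c1ccc(C(F)(F)F)cc1)Nc1cc(-c2ccccc2)[nH]n1`) gives 880 nM as their readings. Compound 2 stands level with compound 1: the two numbers lie within the usual scatter of repeated measurements. These two compounds differ in more than one place, so they cannot show what any single change does.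

The next compound, compound 3 (`COc1ccc(/C=C\C(=O)Nc2cc(-c3ccccc3)[nH]n2)cc1`), differs from compound 2 in one place only. It has methoxy in place of trifluoromethyl on an aromatic carbon, para to a large group (methoxy in place of trifluoromethyl on an aromatic carbon). Within the data shown here, no measured pair shows this swap, so any expectation rests on thin evidence. Compound 1 carries neither group and still gives 1490 nM as its reading, so a large shift is not expected. The estimated step of a 1.5-fold higher number from compound 2 to compound 3 (0.17 log units; within the scatter) is expected to stay within the scatter of this assay and to lean slightly towards weaker inhibition. For compound 3 the expected value is 1300 nM as a middle figure, with an estimated range from 450 nM to 3800 nM around it.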

Compound 3, half-maximal inhibitory concentration: 1060 nM
Beside the measured number, compound 3's estimate is 1.2-fold (0.09 log units) above it; measured number inside the range.
By their numbers in this assay, from the lowest: compounds 2, 3 and 1 (each within the scatter of the next).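

Among these compounds, putting methoxy in place of trifluoromethyl, on an aromatic carbon para to a large group, gives the first reading of a single change: in this assay the step is a 1.2-fold higher number from compound 2 to compound 3 (0.08 log units; within the scatter) and stays within the scatter. At this position, then, the assay does not separate two quite different groups: trifluoromethyl, with its three fluorine atoms and no hydrogen-bond acceptor, and the smaller methoxy, with its oxygen and one hydrogen-bond acceptor. Nothing in the available data explains why these two readings stay level, and this single pair cannot show whether the position tolerates change in general.

From the compounds shown here alone, what an amine, a carboxylic acid or a longer alkoxy chain would do at this same position remains open, as does the reading with a plain hydrogen there. Compound 1 still differs from the other compounds in more than one place, so what its chlorine and its methyl group each contribute also stays unresolved.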